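Open-chain diamine replaces hydroxycyclohexyl on the thioether

The source may report more compounds than this note shows. Statements on the series, on what has been measured and on what is new or still open speak of the compounds shown alone.

Measured compounds:
compound 1 `CC(C)c1n[nH]c2c(NCc3ccc(-c4ccccn4)cc3)nc(SCCNC(=N)N)nc12` gives 390 nM in a functional assay on HT cells (Homo sapiens) for antiproliferative activity, read by fluorescence, with a stated time of 72 h; on this read-out lower numbers stand for stronger inhibition of growth and higher numbers for weaker inhibition of growth;
compound 2 `CC(C)c1n[nH]c2c(NCc3ccc(-c4ccccn4)cc3)nc(SCC(O)CO)nc12` gives 21 nM in this assay;
compound 3 `CC(C)c1n[nH]c2c(NCc3ccc(-c4ccccn4)cc3)nc(SC3CCCCC3O)nc12` gives 636 nM in this assay.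

Compound 3 has the highest number of the three: compound 1 sits nearest to it, within the scatter, while compound 2 is far below it. Compound 4 `CC(C)c1n[nH]c2c(NCc3ccc(-c4ccccn4)cc3)nc(SCC(N)CN)nc12` carries 2,3-diaminopropyl in place of 2-hydroxycyclohexyl on a sulfur.

For the measured compounds named here, two measured steps bear on this. The step of a 30-fold higher number from compound 2 to compound 3 (1.48 log units; beyond the scatter) shows that the open-chain dihydroxypropyl group gave a much lower number than the hydroxycyclohexyl group on the same sulfur. The step of a 19-fold lower number from compound 1 to compound 2 (1.27 log units; beyond the scatter) shows, however, that a nitrogen-rich chain on that sulfur gave a much higher number than the diol. Compound 4 returns to an open chain but bears nitrogens, so a lowering beyond the scatter is expected, though smaller than the step from compound 2 to compound 3. For compound 4 the expected step is a 5.3-fold lower number from compound 3 to compound 4 (0.72 log units; beyond the scatter), and its estimated value is 120 nM, within 25 nM to 550 nM.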

Compound 4, concentration for 50% growth inhibition: 480 nM
Compound 4: middle estimate off by 4.0-fold (0.60 log units), on the low side; low and high end bracket the measured number.
By their numbers in this assay, from the lowest: compound 2; then compounds 1, 4 and 3 (each within the scatter of the next).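

In this assay, an open chain alone proves not to be enough: 1,2-diaminoethyl in place of 1,2-dihydroxyethyl on the saturated chain carbon bound to the sulfur gives a 23-fold higher number from compound 2 to compound 4 (1.36 log units; beyond the scatter). Among these compounds, the low number therefore goes with the diol end rather than with the absence of a ring. Replacing 2-hydroxycyclohexyl with 2,3-diaminopropyl stays within the scatter (a 1.3-fold lower number from compound 3 to compound 4 (0.12 log units; within the scatter)), as does the change between the two nitrogen-bearing chains (a 1.2-fold higher number from compound 1 to compound 4 (0.09 log units; within the scatter)).

Nothing given here explains the gap between diol and diamine. On these data alone, whether a chain ending in one hydroxyl and one amine, or in a carboxylic acid, would fall nearer compound 2 or compound 4 remains open.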